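Fluorophenyl thiosemicarbazones: moving the fluorine

The source may report more compounds than this note shows. Statements on the series, on what has been measured and on what is new or still open speak of the compounds shown alone.

Measured so far in a functional assay on HeLa cells (Homo sapiens) for antiproliferative activity, read by sulforhodamine B assay, with a stated time of 72 h; on this read-out lower numbers stand for stronger inhibition and higher numbers for weaker inhibition: compound 1 `CN(C)C(=S)N/N=C/c1cc2cccnc2s1` gives 48400 nM; compound 2 `FC(F)(F)c1ccccc1NC(=S)N/N=C/c1ccc2ccccc2n1` gives 18800 nM. For compound 3 `Fc1ccccc1NC(=S)N/N=C/c1ccc2ccccc2n1` the read-out is a limit of the assay, > 100000 nM.

For the measured compounds named here, compound 3 thus stands at the limit, the one value of the three without a number, (the limit of > 100000 nM in this assay, at which 1 of the 3 values shown sits). Going by the values given here, the only measured step, an at least 5.3-fold higher number from compound 2 to compound 3 (0.72 log units; beyond the scatter), concerns trifluoromethyl against fluoro and does not cover where a fluorine sits on the ring. Compound 4 `Fc1cccc(NC(=S)N/N=C/c2ccc3ccccc3n2)c1` differs from compound 3 by 3-fluorophenyl in place of 2-fluorophenyl on an amide-type nitrogen. Among the compounds with values here, no measured step bears on this exchange, so the expectation is no step beyond the scatter, a number no higher from compound 3 to compound 4 (the limit leaves the size open). Compound 4 is estimated at 100000 nM, with a range from 30000 nM to 300000 nM, and a limit rather than a number is expected to remain likely.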

Compound 4, half-maximal inhibitory concentration: 70100 nM
Compound 4: middle estimate off by 1.4-fold (0.15 log units), on the high side; low and high end bracket the measured number.
By their numbers in this assay, from the lowest: compound 2; then compounds 1 and 4 (each within the scatter of the next). At a limit, above all of these: compound 3.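

Compound 3 sits at a limit of the assay, > 100000 nM. With 3-fluorophenyl on the amide-type nitrogen, compound 4 gives a measurable number in this assay, 70100 nM. So fluorine placement can decide whether a number is read at all, though the reading is an at least 1.4-fold lower number from compound 3 to compound 4 (0.15 log units; that floor lies within the scatter). The true size of this step stays open: the limit of > 100000 nM in this assay, at which 1 of the 4 values shown sits.

From the compounds shown here alone, whether an amine or a carboxylic acid in that ring's place of the fluorine would shift the number remains open. So does whether a methoxy group would behave like fluoro or trifluoromethyl.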